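The source may hold more compounds than are shown below. What is called first, only, known or untested is meant among the compounds shown, and "the series" means these compounds.

Going by the values given here, compound 2, with the structure `O=C(NCc1cn(Cc2ccc(Cl)cc2)nn1)c1cn(-c2ccccc2)nc1-c1ccc(Cl)cc1`, is the more potent of the two compounds measured so far. In a functional assay on HeLa cells (Homo sapiens) for antiproliferative activity, read by sulforhodamine B assay, with a stated time of 48 h (a lower number here means a stronger inhibitor of growth, a higher number a weaker inhibitor of growth), compound 2 gives 470 nM. The other measured compound, compound 1, has the structure `COc1cc(Cn2cc(CNC(=O)c3cn(-c4ccccc4)nc3-c3ccccc3)nn2)cc(OC)c1` and in this assay compound 1 gives 12200 nM, a number that stands well beyond the scatter above compound 2; these two compounds differ in two places at once, so the figures show only that one is much weaker than the other, not which change is responsible.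

Compound 3, with the structure `COc1cc(Cn2cc(CNC(=O)c3cn(-c4ccccc4)nc3-c3ccc(Cl)cc3)nn2)cc(OC)c1`, is the next step from compound 2. Among the compounds with values here, the change is 3,5-dimethoxyphenyl in place of 4-chlorophenyl on a saturated chain carbon bound to an aromatic nitrogen, so compound 3 carries the 3,5-dimethoxybenzyl group of compound 1 together with the 4-chlorophenyl group of compound 2, and no single-change step of this kind has been measured. Given that compound 1 with the same 3,5-dimethoxybenzyl group gives 12200 nM, the expected step of a 6.4-fold higher number from compound 2 to compound 3 (0.81 log units; beyond the scatter) is a loss of potency beyond the scatter. Compound 3 is therefore estimated at 3000 nM, with a range from 700 nM to 13000 nM.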

Compound 3, concentration for 50% growth inhibition: 730 nM
Compound 3: the middle estimate sits 4.1-fold (0.61 log units) above what was measured, and the stated range covers the measured number.
By their numbers in this assay, from the lowest: compounds 2 and 3 (each within the scatter of the next); then compound 1.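

In this assay the exchange of 4-chlorobenzyl for 3,5-dimethoxybenzyl, on a saturated chain carbon bound to an aromatic nitrogen, gives a 1.6-fold higher number from compound 2 to compound 3 (0.19 log units; within the scatter) and so makes no measurable difference here, even though the entering group is larger and carries two oxygen atoms. With the 3,5-dimethoxybenzyl group held constant, chloro in place of hydrogen on an aromatic carbon gives a 17-fold lower number from compound 1 to compound 3 (1.22 log units; beyond the scatter) as a large gain, so the poor number of compound 1 goes with the missing chloro and not with its 3,5-dimethoxybenzyl group. No supporting measurement is available to explain either result.

Still open, going by these compounds, is whether bromo or methyl could stand in place of that chloro and keep the gain, and whether a compound with the 4-chlorobenzyl group depends on the chloro to the same extent. On these data alone, it is also open how far the tolerance at the benzyl group extends, for instance to a benzyl ring carrying an amine or a carboxylic acid.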